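Cyclohexyl for 4-ethylphenyl on the amine nitrogen

A few compounds are considered here, and "the series" means these few. Any claim that something is new, unique, unknown or untested is made for them only; others in the source may bear on it.

The series shares one core, carried by compound 1 `COc1cccc(NC2=CC(=O)c3c(nc4n3[C@H]3OC[C@@H](O)[C@H]3OC4)C2=O)c1`, compound 2 `CCCc1ccc(NC2=CC(=O)c3c(nc4n3[C@H]3OC[C@@H](O)[C@H]3OC4)C2=O)cc1` and compound 3 `CCc1ccc(NC2=CC(=O)c3nc4n(c3C2=O)[C@H]2OC[C@@H](O)[C@H]2OC4)cc1`. In a functional assay on ECa-109 cells for inhibition, with ECa-109 cell line (Homo sapiens) as the target, read by sulforhodamine B assay (a higher number here means a weaker inhibitor, a lower number a stronger inhibitor), compound 1 gives 3340 nM. Going by the values given here, compound 3 gives 3080 nM in this assay, one of only two numbers in the set, the other, from compound 1, sitting within the scatter of it. For compound 2 this assay reports only a limit, > 4000 nM, at the limit of > 4000 nM in this assay, at which 1 of the 3 values shown sits. Among the compounds with values here, the single measured step, an at least 1.1-fold higher number from compound 1 to compound 2 (0.07 log units; that floor lies within the scatter), stays within the scatter. Compound 4 `O=C1C=C(NC2CCCCC2)C(=O)c2c1nc1n2[C@H]2OC[C@@H](O)[C@H]2OC1` differs from compound 3 by cyclohexyl in place of 4-ethylphenyl on an amine nitrogen. Within the data shown here, no measured step exchanges an aromatic ring for a non-aromatic one, so the step of a 1.3-fold higher number from compound 3 to compound 4 (0.11 log units; within the scatter) is expected to be small and of uncertain direction. Compound 4 is estimated at 4000 nM, between 1500 nM and 10000 nM.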

Compound 4, half-maximal inhibitory concentration: > 16000 nM
Compound 4: no number, only a limit; the forecaster's own chance of this, stated with the estimate: 45%; middle value at least 4.0-fold (0.60 log units) from the limit.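

Going by these compounds alone, the amine nitrogen substituent now shows a real effect in this assay: the step of an at least 5.1-fold higher number from compound 3 to compound 4 (0.71 log units; beyond the scatter) is the first beyond the scatter, whereas the aryl-for-aryl step an at least 1.1-fold higher number from compound 1 to compound 2 (0.07 log units; that floor lies within the scatter) stayed within it. On this evidence, cyclohexyl is not tolerated like the 4-ethylphenyl it replaces. Compound 4 gives a limit, not a number, so the true size of the step remains unknown: the limit of > 16000 nM in this assay, at which 1 of the 4 values shown sits.

Still open, from the compounds shown here alone, is whether the non-aromatic ring or the missing ethyl drives the step. An unsubstituted phenyl or a 4-ethylcyclohexyl on the amine nitrogen would separate the two.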